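Trimming the dimethylsulfamoyl group of compound 3

The compounds below may be only part of what the source reports. "The series", "measured", "known", "first", "only" and "open" are said of these compounds alone.

Compound 1 `CN(C)C(=O)c1cccc(C#Cc2cc(Cl)ccc2OCC(=O)O)c1`: 52 nM
Compound 2 `CS(=O)(=O)c1cccc(C#Cc2cc(Cl)ccc2OCC(=O)O)c1`: 15 nM
Compound 3 `CN(C)S(=O)(=O)c1cccc(C#Cc2cc(Cl)ccc2OCC(=O)O)c1`: 14 nM

Three compounds share one core and differ only in the group carried on an aromatic carbon. In an assay on CHO cells for displacement of a labelled ligand from prostaglandin D2 receptor 2 (Homo sapiens), read by scintillation counting (a lower number here means a stronger inhibitor, a higher number a weaker inhibitor), compound 1 gives 52 nM, compound 2 gives 15 nM and compound 3 gives 14 nM. Compound 3 has the lowest number of the three, but its gap to compound 2 lies within the scatter (a 1.1-fold lower number from compound 2 to compound 3 (0.03 log units; within the scatter)), so the two cannot be told apart; only its separation from compound 1 is real (a 3.7-fold lower number from compound 1 to compound 3 (0.57 log units; beyond the scatter)), as is that of compound 2 (a 3.5-fold lower number from compound 1 to compound 2 (0.54 log units; beyond the scatter)).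

Compound 4 `C[S+]([O-])c1cccc(C#Cc2cc(Cl)ccc2OCC(=O)O)c1` has not yet been measured. It differs from compound 3 as follows: a group of 3 heavy atoms (1 carbon, 1 oxygen, 1 sulfur; no ring) in place of a group of 6 heavy atoms (2 carbon, 1 nitrogen, 2 oxygen, 1 sulfur; no ring), on an aromatic carbon. Two kinds of measured step bear on this. The step from compound 2 to compound 3 shows that dimethylamino in place of methyl on the sulfonyl sulfur changes nothing beyond the scatter, while the steps from compound 1 show that both sulfonyl-bearing compounds sit modestly below the dimethylcarbamoyl compound. Going by the values given here, no measured pair, however, changes the number of oxygens on the sulfur, so the move to a group of 3 heavy atoms is untested. A modest rise in the number is expected for compound 4, a 2.5-fold higher number from compound 3 to compound 4 (0.40 log units; beyond the scatter). Compound 4 is therefore estimated at 35 nM in this assay, with a range from 12 nM to 100 nM.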

Compound 4, inhibition constant: 3.2 nM
For compound 4 the middle estimate is 11-fold (1.04 log units) above the measured one; measured number outside the range, below it.
By their numbers in this assay, from the lowest: compound 4; then compounds 3 and 2 (each within the scatter of the next); then compound 1.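

In this assay this aromatic carbon proves to accept a much smaller group with a gain rather than a loss: the group of 3 heavy atoms gives a 4.4-fold lower number from compound 3 to compound 4 (0.64 log units; beyond the scatter) and a 4.7-fold lower number from compound 2 to compound 4 (0.67 log units; beyond the scatter), a separation that dimethylsulfamoyl and methylsulfonyl, within the scatter of each other, had not shown. Against dimethylcarbamoyl the change is larger, a 16-fold lower number from compound 1 to compound 4 (1.21 log units; beyond the scatter), and the series does not simply follow group size, since compound 4 carries the smallest group and the lowest number, while compound 3, with the largest group, still sits below compound 1. Nothing measured alongside these compounds accounts for the size or direction of these steps.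

Still open, on these data alone, is whether the lower number follows from having a single oxygen on the sulfur or from the smaller group as a whole, a question that a methylthio group, with no oxygen on the sulfur, would help to separate. As far as these compounds go, it is also open how far the position tolerates change around the sulfur, for instance an ethyl or a longer chain in place of the methyl.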